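Oxime ether series: acid replaces isopropyl on compound 2

A few compounds are considered here, and "the series" means these few. Any claim that something is new, unique, unknown or untested is made for them only; others in the source may bear on it.

Measured so far:
compound 1 `CO[C@]1(c2cnc(Sc3ccc(/C(C)=N/O)cc3)s2)CCO[C@@H](C)C1` gives 40 nM in a functional assay (blood) for inhibition, with Homo sapiens as the target; on this read-out lower numbers stand for stronger inhibition and higher numbers for weaker inhibition
compound 2 `C/C(=N\OC(C)C)c1ccc(Sc2cc(F)cc(C3CCOCC3)c2)cc1` gives 920 nM in this assay

Among the compounds with values here, compound 2 holds the higher of the two numbers; compound 1 is the only neighbour, and the gap between them lies beyond the scatter. Compound 3 `C/C(=N\OCC(=O)O)c1ccc(Sc2cc(F)cc(C3CCOCC3)c2)cc1` differs from compound 2 by the change (carboxymethyl in place of isopropyl on an oxygen). Within the data shown here, no step of this kind is measured, so the direction rests on nothing firmer than the single pair in hand. A step of a 1.6-fold higher number from compound 2 to compound 3 (0.21 log units; within the scatter) is expected, small and toward weaker inhibition. Compound 3 is estimated at 1500 nM, within 400 nM to 6000 nM.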

Compound 3, half-maximal inhibitory concentration: 740 nM
For compound 3 the middle estimate is 2.0-fold (0.31 log units) above the measured one; the measured number falls inside the stated range.
By their numbers in this assay, from the lowest: compound 1; then compounds 3 and 2 (each within the scatter of the next).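

With carboxymethyl in place of isopropyl on an oxygen whose other neighbour is the double-bonded nitrogen, the series shows a 1.2-fold lower number from compound 2 to compound 3 (0.09 log units; within the scatter) in this assay and so no change beyond the scatter. This position therefore accepts a group with a hydrogen-bond donor and a hydrogen-bond acceptor without a measurable shift, on this single pair. No evidence in hand bears on this result.

Open, going by these compounds, are the methyl ester of carboxymethyl, a longer chain ending in a carboxylic acid, and an amine on the same oxygen. Also open, on these data alone, is whether the same change reads alike on the core of compound 1.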